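This account rests on a few compounds, and the source may have more. Where it says the series, first, only, none or still open, it means among the compounds named here.

Compound 1, `COc1ccc(-c2[nH]c3ccccc3c2/C=C(\C#N)S(=O)(=O)c2ccccc2)cc1`: > 100000 nM
Compound 2, `COc1ccc(-c2[nH]c3ccc(OC)cc3c2/C=C(\C#N)S(=O)(=O)c2ccccc2)cc1`: > 100000 nM
Compound 3, `CCOC(=O)/C(=C/c1c(-c2ccccc2)[nH]c2ccccc12)C(=O)c1ccc([N+](=O)[O-])cc1`: > 100000 nM

In a functional assay on SK-MEL-28 cells (Homo sapiens) for cytotoxicity, read by MTT assay, with a stated time of 96 h (on this read-out higher numbers stand for an effect only at larger amounts of compound and lower numbers for an effect already at smaller amounts), compound 1 gives no number but only the assay's limit, > 100000 nM. Compound 2 likewise gives only a limit in this assay, > 100000 nM. Compound 3, built on a different core, also stops at a limit in this assay, > 100000 nM. Compound 2 therefore stands at the limit where every shown value sits (the limit of > 100000 nM in this assay, at which 3 of the 3 values shown sit), and it cannot be ranked against compound 1 or compound 3. Within the data shown here, the single step between measured compounds, a step that the two limits leave unreadable from compound 1 to compound 2, adds a methoxy to the core of compound 1, and with both ends at the limit its size is not readable.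

Compound 4, `COc1ccc2[nH]c(-c3ccccc3)c(/C=C(\C#N)S(=O)(=O)c3ccccc3)c2c1`, removes the other methoxy: hydrogen in place of methoxy on an aromatic carbon. No measured step covers this change; the one shown step, a step that the two limits leave unreadable from compound 1 to compound 2, concerns the methoxy on the core and is itself unreadable. What is known is that three of three values rest at the limit (the limit of > 100000 nM in this assay, at which 3 of the 3 values shown sit). Compound 4 is therefore expected to stay near that limit, with a step that the limit leaves unreadable from compound 2 to compound 4 expected to be no step beyond the scatter. Compound 4 is estimated at 150000 nM, within 50000 nM to 500000 nM, and most probably reported again only as a limit.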

Compound 4, half-maximal effective concentration: 10000 nM
Compound 4: the middle estimate sits 15-fold (1.18 log units) above what was measured, and the stated range ends above it.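

In this assay, putting hydrogen in place of methoxy on the 4-methoxyphenyl group gives an at least 10-fold lower number from compound 2 to compound 4 (1.00 log units; beyond the scatter), and this is the only step shown that can be read. It shows that this position, on an aromatic carbon of a six-membered aromatic ring of carbon only and para to a large group, is one where a single change brings the read-out off the limit, something the unreadable step on the core could not show. Compound 4 is the only compound shown with a number rather than a limit of the assay: the limit of > 100000 nM in this assay, at which 3 of the 4 values shown sit.

The true size of the step stays open, as compound 2 has only a limit, and nothing shown says whether the gain comes from losing the methoxy as such or would also appear with a hydroxyl group, a chlorine or an ethoxy at this position. From the compounds shown here alone, it is also open whether the change from 4-methoxyphenyl to phenyl would have the same outcome on the core of compound 1, which carries hydrogen where compound 4 carries methoxy.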